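A Chloro Added to a Sulfonamide at the Assay Limit

The source may report more compounds than this note shows. Statements on the series, on what has been measured and on what is new or still open speak of the compounds shown alone.

Three sulfonamides on one carboxylic acid core were examined in a functional assay (plasma) for inhibition, with Oryctolagus cuniculus as the target; on this read-out lower numbers stand for stronger inhibition and higher numbers for weaker inhibition. Compound 1 `CC(C)c1ccc2c(CCCNS(=O)(=O)c3ccccc3)cc(C(=O)O)c-2cc1` gives only the limit > 100000 nM, not a number. Compound 2 `CC(C)c1ccc2c(CCCCNS(=O)(=O)c3ccccc3)cc(C(=O)O)c-2cc1` likewise reaches only the limit > 100000 nM. Compound 3 `CC(C)c1ccc2c(CCCCCNS(=O)(=O)c3ccccc3)cc(C(=O)O)c-2cc1` sits at the limit > 100000 nM too. For the measured compounds named here, compound 2 therefore stands where every value shown stands, namely at the limit of > 100000 nM in this assay, at which 3 of the 3 values shown sit, and no step between measured compounds is known. Compound 4 `CC(C)c1ccc2c(CCCCNS(=O)(=O)c3ccc(Cl)cc3)cc(C(=O)O)c-2cc1` differs from compound 2 by chloro in place of hydrogen on an aromatic carbon. The expected step is none beyond the scatter, with a limit again the most likely outcome, a step that the limit leaves unreadable from compound 2 to compound 4. Compound 4 is estimated in this assay at 150000 nM, within 30000 nM to 1000000 nM.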

Compound 4, half-maximal inhibitory concentration: > 100000 nM
Compound 4 gave a limit, no number (the forecaster's own chance of this, stated with the estimate: 85%); the middle value does not contradict the limit.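

For the compounds shown here, compound 2 and compound 4 both gave only a limit, so no step between them can be read: the limit of > 100000 nM in this assay, at which 4 of the 4 values shown sit. The compounds shown leave open whether the chloro changes inhibition at all, since none of them yields a number.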